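This account rests on a few compounds, and the source may have more. Where it says the series, first, only, none or still open, it means among the compounds named here.

Measured so far in a functional assay on thoracic aorta (Rattus norvegicus, strain Wistar), with a stated time of 15 min; on this read-out higher numbers stand for an effect only at larger amounts of compound and lower numbers for an effect already at smaller amounts:
- compound 1, `Cc1ccc(S(=O)(=O)NC(=O)NC(C)c2cc(Br)ccc2OCc2ccccc2)cc1`: 138000 nM
- compound 2, `Cc1ccc(S(=O)(=O)NC(=O)NC(C)c2ccccc2OCc2ccccc2)cc1`: compound 2 reports only a limit, > 200000 nM
- compound 3, `CC(NC(=O)NS(=O)(=O)c1ccc(Cl)cc1)c1cc(Br)ccc1OCc1ccccc1`: 57500 nM

Compound 1 gives the highest of the two numbers in this assay; its nearest neighbour is compound 3, which differs by chloro in place of methyl on an aromatic carbon, a step of a 2.4-fold lower number from compound 1 to compound 3 (0.38 log units; beyond the scatter). The step to compound 2, hydrogen in place of bromo on an aromatic carbon, reads an at least 1.4-fold higher number from compound 1 to compound 2 (0.16 log units; that floor lies within the scatter), and it rests on a limit (the limit of > 200000 nM in this assay, at which 1 of the 3 values shown sits).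

Compound 4, `CCOc1ccc(Br)cc1C(C)NC(=O)NS(=O)(=O)c1ccc(C)cc1`, is not yet measured. It differs from compound 1 as follows: methyl in place of phenyl on a saturated chain carbon bound to an oxygen on an aromatic ring. Neither measured step touches this place, so there is no direct guide. Both shown steps are small; the change here removes a large part of the molecule, and a shift in either direction beyond the scatter cannot be ruled out. On balance a somewhat higher number is expected, and a limit result is a real possibility. Compound 4 is estimated at 200000 nM in this assay, range 70000 nM to 600000 nM, an expected step of a 1.4-fold higher number from compound 1 to compound 4 (0.16 log units; within the scatter).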

Compound 4, half-maximal effective concentration: > 300000 nM
Compound 4 ended at the assay's limit; the forecaster's own chance of this, stated with the estimate: 50%; at least 1.5-fold (0.17 log units) between middle value and limit.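

Among these compounds, the earlier steps touched only the bromo and the methyl on aromatic carbons, and this is the first reading at the benzyloxy group: in this assay, benzyloxy to ethoxy gives an at least 2.1-fold higher number from compound 1 to compound 4 (0.33 log units; beyond the scatter). Unlike the floor of the step to compound 2, this floor lies beyond the scatter, so methyl in place of phenyl at this place moves the read-out towards larger amounts of compound by a margin that can be read. Compound 4 reports only a limit, so the full size of the step stays unknown: the limit of > 300000 nM in this assay, at which 1 of the 4 values shown sits.

Open, from the compounds shown here alone, is whether a longer chain or a cyclohexyl in place of the phenyl would keep the reading of compound 1. Also open, going by these compounds, is whether chloro in place of methyl on an aromatic carbon, as in compound 3, would bring a lower number on an ethoxy compound.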